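The compounds below may be only part of what the source reports. "The series", "measured", "known", "first", "only" and "open" are said of these compounds alone.

Working notes on the series. For the measured compounds named here, compound 1 `CCOC(=O)CN(C)C(=O)OCN(c1ccc([N+](=O)[O-])cc1Oc1ccccc1)S(C)(=O)=O` is the longer-lasting of the two compounds so far measured in an ADME assay on a cell-free system (plasma, Homo sapiens) for metabolic stability; a lower number here means that the compound disappears faster, a higher number that the compound lasts longer: compound 1 gives 49.2 h, whereas compound 2 `CCCCC(=O)OCOC(=O)Cc1c(C)n(C(=O)c2ccc(Cl)cc2)c2ccc(OC)cc12` in this assay gives 2.07 h, a gap beyond the scatter. Compound 3 `CCOC(=O)CNC(=O)OCN(c1ccc([N+](=O)[O-])cc1Oc1ccccc1)S(C)(=O)=O` has yet to be measured in this assay. It differs from compound 1 in one place: hydrogen in place of methyl on an amide-type nitrogen. Going by the values given here, no measured pair shows this change, so the step of a 1.2-fold lower number from compound 1 to compound 3 (0.09 log units; within the scatter) is expected to remain within the scatter, in either direction. Compound 3 is accordingly estimated at 40 h, within a range from 15 h to 100 h.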

Compound 3, half-life: 15.9 h
Compound 3: the middle estimate sits 2.5-fold (0.40 log units) above what was measured; measured number inside the range.
By their numbers in this assay, from the lowest: compound 2; then compound 3; then compound 1.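

Hydrogen in place of methyl on the amide-type nitrogen is the first single change that can be read in the series. In this assay it gives a 3.1-fold lower number from compound 1 to compound 3 (0.49 log units; beyond the scatter) and so shows that what sits on this nitrogen matters for the half-life, with the methyl form lasting longer. Nothing at hand bears on why this step occurs.

From the compounds shown here alone, how a longer chain such as ethyl on this nitrogen would compare with methyl and hydrogen remains open. So does whether the same change gives a similar step on another core.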